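This account rests on a few compounds, and the source may have more. Where it says the series, first, only, none or still open, it means among the compounds named here.

Compound 1 `COc1ccc(-c2c(C#N)c(N)nc(SCc3csc(-c4ccc(Br)cc4)n3)c2C#N)cc1`: 3.8 nM
Compound 2 `COc1ccc(-c2c(C#N)c(N)nc(SCc3csc(-c4ccc(Br)cn4)n3)c2C#N)cc1`: 53 nM
Compound 3 `COc1ccc(-c2c(C#N)c(N)nc(SCc3csc(-c4ccc(F)cc4)n3)c2C#N)cc1`: 2.3 nM

In an assay on CHO cells for displacement of a labelled ligand from adenosine receptor A1 (Homo sapiens) (a lower number here means a stronger inhibitor, a higher number a weaker inhibitor), compound 3 holds the lowest of the three numbers. The step of a 1.7-fold lower number from compound 1 to compound 3 (0.22 log units; within the scatter) stays within the scatter, so compound 1 and compound 3 cannot be ordered; the step of a 23-fold lower number from compound 2 to compound 3 (1.36 log units; beyond the scatter) is large, as is the step of a 14-fold higher number from compound 1 to compound 2 (1.14 log units; beyond the scatter), and compound 2 stands clearly apart.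

Compound 4 `COc1ccc(-c2c(C#N)c(N)nc(SCc3cscn3)c2C#N)cc1` differs from compound 3 by hydrogen in place of 4-fluorophenyl on an aromatic carbon, on an aromatic carbon of the five-membered aromatic ring with 1 nitrogen and 1 sulfur. Two kinds of step bear on this. Swapping the halogen on the six-membered ring, the step of a 1.7-fold lower number from compound 1 to compound 3 (0.22 log units; within the scatter), changed little. Replacing that ring by a 5-bromopyridin-2-yl, the steps of a 14-fold higher number from compound 1 to compound 2 (1.14 log units; beyond the scatter) and a 23-fold lower number from compound 2 to compound 3 (1.36 log units; beyond the scatter), cost a great deal. Removing the whole 4-fluorophenyl goes further than either, so a large rise in this assay is expected, well beyond the scatter. For compound 4 the expected value is 200 nM, with a range from 40 nM to 1000 nM, corresponding to an estimated step of an 87-fold higher number from compound 3 to compound 4 (1.94 log units; beyond the scatter).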

Compound 4, inhibition constant: 1.3 nM
Compound 4: the middle estimate sits 150-fold (2.19 log units) above what was measured, outside the stated range (below it).
By their numbers in this assay, from the lowest: compounds 4, 3 and 1 (each within the scatter of the next, the first and the last beyond it); then compound 2.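

In this assay, the 4-fluorophenyl on this aromatic carbon of the five-membered aromatic ring can be replaced by hydrogen with no readable change: a 1.8-fold lower number from compound 3 to compound 4 (0.25 log units; within the scatter) stays within the scatter. Against the other aryl groups, the same hydrogen gives a 2.9-fold lower number from compound 1 to compound 4 (0.47 log units; beyond the scatter), a modest step, and a 41-fold lower number from compound 2 to compound 4 (1.61 log units; beyond the scatter), a large one. The position therefore needs no six-membered ring for a low number, and the high number belongs to the 5-bromopyridin-2-yl specifically, as a penalty seen against hydrogen as well as against both halogenated phenyl groups.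

From the compounds shown here alone, whether a methyl, an aminomethyl or a carboxylic acid on this carbon would stay with these low numbers remains open. Nothing available here accounts for the gap between the 5-bromopyridin-2-yl and hydrogen.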